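A few compounds are considered here, and "the series" means these few. Any claim that something is new, unique, unknown or untested is made for them only; others in the source may bear on it.

Within the data shown here, in a functional assay on HeLa cells (Homo sapiens) for cytotoxicity, read by WST assay, with a stated time of 48 h (on this read-out lower numbers stand for stronger inhibition and higher numbers for weaker inhibition), compound 1 `COc1cccc(/C=C/C[C@H]2C[C@@H]([C@@H](O)c3ccccc3)CO[C@@H]2c2ccccc2)c1` gives 10900 nM, the only actual number so far. Compound 2 `COc1ccc(/C=C/C[C@@H]2C[C@@H]([C@@H](OC)c3ccc(OC)c(OC)c3)CO[C@H]2c2ccc(OC)c(OC)c2)cc1OC` reads > 100000 nM, a limit of the assay and not a number. Compound 3 `COc1ccc(/C=C/C[C@H]2C[C@@H]([C@@H](OC(C)=O)c3ccc(OC)c(OC)c3)CO[C@@H]2c2ccc(OC)c(OC)c2)cc1OC` reads > 100000 nM, again a limit. Compound 4 `Cc1ccc(/C=C/C[C@H]2C[C@@H]([C@@H](O)c3ccccc3)CO[C@@H]2c2ccccc2)cc1C` keeps the core of compound 1 and carries 3,4-dimethylphenyl in place of 3-methoxyphenyl on a double-bonded chain carbon bound to a double-bonded chain carbon. Among the measured compounds shown here, no measured pair shows this change, so nothing beyond the scatter is expected in this assay, in either direction. The expected step of a 1.2-fold lower number from compound 1 to compound 4 (0.08 log units; within the scatter) is therefore small, and the estimate stays anchored on compound 1 at 10900 nM. For compound 4 the estimated value is 9000 nM, with a range of 3500 nM to 25000 nM.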

Compound 4, half-maximal inhibitory concentration: 10000 nM
Compound 4: middle estimate off by 1.1-fold (0.05 log units), on the low side, within the range that was stated.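

In this assay, among these compounds, the only step that can be read at this position is a 1.1-fold lower number from compound 1 to compound 4 (0.04 log units; within the scatter). On a double-bonded chain carbon bound to a double-bonded chain carbon, 3,4-dimethylphenyl therefore sits within the scatter of 3-methoxyphenyl, even though the hydrogen-bond acceptor of the leaving group is absent from the entering one. Among the compounds shown here, compounds 2 and 3 each read as a limit, not a number, so no step to them can be read: the limit of > 100000 nM in this assay, at which 2 of the 4 values shown sit. Still open, from the compounds shown here alone, is whether an amine or a carboxylic acid on this phenyl ring would stay within the same scatter. The same holds for a longer chain in place of the ethenyl link.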